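The source may report more compounds than this note shows. Statements on the series, on what has been measured and on what is new or still open speak of the compounds shown alone.

Measured series, activity in a functional assay on Ehrlich cells (Mus musculus) for antiproliferative activity, read by trypan blue exclusion, with a stated time of 2 h, tested at 25 ug/mL; on this read-out higher numbers stand for a stronger effect at the one concentration tested and lower numbers for a weaker effect:
- compound 1 `N#CC1=C(N)N(c2ccc(S(N)(=O)=O)cc2)C2=C(C(=O)CCC2)C1c1ccc(O)cc1`: 95%
- compound 2 `COc1ccc(C2C(C#N)=C(N)N(c3ccc(S(N)(=O)=O)cc3)C3=C2C(=O)CCC3)cc1`: 50%
- compound 3 `N#CC1=C(N)N(c2ccc(S(N)(=O)=O)cc2)C2=C(C(=O)CCC2)C1c1cccc([N+](=O)[O-])c1`: 50%

Compound 3 sits level with compound 2 in this assay, the two together forming the lowest pair of the three numbers; compound 1 stands well above both. The steps that lower the read-out are a number 45 percentage points lower from compound 1 to compound 2 (beyond the scatter) and a number 45 percentage points lower from compound 1 to compound 3 (beyond the scatter), whereas no change at the digits printed from compound 2 to compound 3 (within the scatter) shows that swapping one aryl group lacking a hydroxyl for another leaves the number where it is.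

Compound 4 `N#CC1=C(N)N(c2ccc(S(N)(=O)=O)cc2)C2=C(C(=O)CCC2)C1c1ccc(Cl)cc1Cl` is the next target. Its change from compound 3: 2,4-dichlorophenyl in place of 3-nitrophenyl on a saturated ring carbon. Among the compounds with values here, the only step bearing on it, from compound 2 to compound 3, was flat, so a step of about the same size is expected, no change at the digits printed from compound 3 to compound 4 (within the scatter). Compound 4 is therefore estimated at 50%, range 30% to 75%.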

Compound 4, a percentage reported as activity, at one concentration (the size of the read-out at that concentration, not a potency): 50%
The estimate for compound 4 equals the measured number at the digits printed, and the stated range covers the measured number.
By their numbers in this assay, from the lowest: compounds 2, 3 and 4 (each within the scatter of the next); then compound 1.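

At this saturated ring carbon, this assay gives no change at the digits printed from compound 3 to compound 4 (within the scatter) and also no change at the digits printed from compound 2 to compound 4 (within the scatter) for 2,4-dichlorophenyl, so a chlorinated aryl group joins 3-nitrophenyl and 4-methoxyphenyl at the same level. With a number 45 percentage points lower from compound 1 to compound 4 (beyond the scatter) as well, compound 1 and its 4-hydroxyphenyl group stay alone at the top of the four compounds. Nothing available explains this shared level.

Still open, on these data alone, is whether the high read-out of compound 1 needs a hydroxyl specifically, or whether a 4-aminophenyl or 4-carboxyphenyl group would match it. A 3-hydroxyphenyl group at this carbon would test whether the hydroxyl's ring position matters.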